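The source may hold more compounds than are shown below. What is called first, only, known or untested is meant among the compounds shown, and "the series" means these compounds.

Working notes on the series. In an assay on isolated protein for inhibition of Amine oxidase [flavin-containing] A (Homo sapiens), read by fluorescence, with stated times of 15 min and 20 min (a lower number here means a stronger inhibitor, a higher number a weaker inhibitor), compound 1 `CC(C)(C)c1cc(CCC(=O)NCCC2CCN(Cc3ccccc3)CC2)cc(C(C)(C)C)c1O` gives 94100 nM, compound 2 `COc1ccc(CN2CCC(CCNC(=O)/C=C/c3cc(C(C)(C)C)c(O)c(C(C)(C)C)c3)CC2)cc1` gives 72500 nM and compound 3 `Cc1ccc(CN2CCC(CCNC(=O)/C=C/c3cc(C(C)(C)C)c(O)c(C(C)(C)C)c3)CC2)cc1` gives 70100 nM. Compound 3 holds the lowest number of the three, but compound 1 and compound 2 sit within the scatter of it, so no order is claimed. For the measured compounds named here, the one step that touches the benzyl substituent, a 1.0-fold lower number from compound 2 to compound 3 (0.01 log units; within the scatter), lies within the scatter. Compound 4 `CC(C)(C)c1cc(/C=C/C(=O)NCCC2CCN(Cc3cccc([N+](=O)[O-])c3)CC2)cc(C(C)(C)C)c1O` carries 3-nitrophenyl in place of 4-methylphenyl on a saturated chain carbon bound to an amine nitrogen in a ring. Going by the values given here, no measured step changes the benzyl substituent beyond the scatter, and the two nitro acceptors entering have no precedent here; a step in this assay beyond the scatter is therefore not expected. The estimate for compound 4 is 70000 nM, ranging from 35000 nM to 140000 nM, an expected step of a 1.0-fold lower number from compound 3 to compound 4 (0.00 log units; within the scatter).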

Compound 4, half-maximal inhibitory concentration: 70900 nM
For compound 4 the middle estimate is 1.0-fold (0.01 log units) below the measured one; measured number inside the range.
By their numbers in this assay, from the lowest: compounds 3, 4, 2 and 1 (each within the scatter of the next).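

In this assay, 3-nitrophenyl in place of 4-methylphenyl gives a 1.0-fold higher number from compound 3 to compound 4 (0.00 log units; within the scatter) and 3-nitrophenyl in place of 4-methoxyphenyl gives a 1.0-fold lower number from compound 2 to compound 4 (0.01 log units; within the scatter) at this place, on a saturated chain carbon bound to an amine nitrogen in a ring. The position thus takes a nitro-bearing group with two hydrogen-bond acceptors with no step beyond the scatter, where earlier only methyl against methoxy could be compared. No evidence bearing on this result is available.

As far as these compounds go, whether an amine or a carboxylic acid on this phenyl group would give a step beyond the scatter stays open. No one-place step shown tests the shared core.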